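Purine benzyl chlorides: loss of a chloro substituent

The compounds below may be only part of what the source reports. "The series", "measured", "known", "first", "only" and "open" are said of these compounds alone.

Compound 3 `ClCc1cccc(Cn2cnc3c(Cl)nc(Cl)nc32)c1` and compound 1 `ClCc1cccc(Cn2cnc3c(Cl)ncnc32)c1` share one core and differ only in a single substituent. In a functional assay on SF-539 cells (Homo sapiens) for cytotoxicity, read by sulforhodamine B assay, with a stated time of 48 h (a lower number here means that less compound is tolerated, a higher number that more compound is tolerated), compound 3 gives 40700 nM, while compound 1 gives 61700 nM. The change between them, (hydrogen in place of chloro on an aromatic carbon), made a step of a 1.5-fold higher number from compound 3 to compound 1 (0.18 log units; within the scatter). Compound 2 `ClCc1ccc(Cn2cnc3nc(Cl)nc(Cl)c32)cc1` carries the same atoms as compound 3 joined differently; the difference between the two cores is not broken down here. In this assay compound 2 gives 5880 nM, the lowest of the three numbers, beyond the scatter from both others.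

Compound 4 `ClCc1ccc(Cn2cnc3ncnc(Cl)c32)cc1` is not yet measured in this assay. It stands to compound 2 as compound 1 stands to compound 3: the change is hydrogen in place of chloro on an aromatic carbon, the same change at a place described in the same words. Within the data shown here, the one measured instance of this change, a 1.5-fold higher number from compound 3 to compound 1 (0.18 log units; within the scatter), sat within the scatter, so from compound 2 to compound 4 a step of about a 1.4-fold higher number from compound 2 to compound 4 (0.16 log units; within the scatter) is expected, resting on that single precedent and the value of compound 2, 5880 nM. For compound 4 a value near 8500 nM is estimated, expected to fall between 3500 nM and 21000 nM.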

Compound 4, concentration lethal to 50% of the cells: 6760 nM
For compound 4 the middle estimate is 1.3-fold (0.10 log units) above the measured one; measured number inside the range.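

In this assay, hydrogen in place of chloro on an aromatic carbon gives a 1.1-fold higher number from compound 2 to compound 4 (0.06 log units; within the scatter) and so stays within the scatter on the core of compound 2, as it does on the core of compound 3. The two instances of the change agree with each other: the same change on two cores in this assay, a 1.5-fold higher number (0.18 log units; within the scatter) from compound 3 to compound 1 and a 1.1-fold higher number (0.06 log units; within the scatter) from compound 2 to compound 4, 1.3-fold (0.12 log units) apart, within the scatter of two such steps.

Within this assay, the chloro group at this place can be exchanged for hydrogen on either core without a readable step, but two pairs show only that, and they give no general rule for other cores or other cell lines, nor do they account for the difference between the two cores themselves.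

The compounds shown leave open what an amine or a methoxy group would do in place of this chloro group. Also open, going by these compounds, is whether the chloromethyl group matters, for which a comparison with a hydroxymethyl or plain methyl group on the same core would be needed.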